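From Fluoro to Sulfamoyl: An Expected Binding Shift

This account rests on a few compounds, and the source may have more. Where it says the series, first, only, none or still open, it means among the compounds named here.

Of the compounds shown here, two have been tested in an in vitro assay on HEK385-7 cells for displacement of a labelled ligand from prostaglandin D2 receptor 2 (Homo sapiens); a higher number here means a weaker inhibitor, a lower number a stronger inhibitor. Compound 1 `O=C(O)Cc1sc(C(c2ccccc2)c2ccc(O)cc2)nc1-c1ccc(F)cc1` gives 3.4 nM. Compound 2 `O=C(O)Cc1sc(C(c2ccc(F)cc2)c2ccc(F)cc2)nc1-c1cccc(F)c1` gives 1.4 nM, the lower of the two numbers, and its gap to compound 1 lies beyond the usual scatter, so compound 2 is the stronger inhibitor of the pair. The next compound, compound 3 `NS(=O)(=O)c1cccc(-c2nc(C(c3ccc(F)cc3)c3ccc(F)cc3)sc2CC(=O)O)c1`, differs from compound 2 in a single place: sulfamoyl in place of fluoro on an aromatic carbon. A small fluoro gives way to a sulfamoyl on an aromatic carbon of a six-membered aromatic ring of carbon only, meta to a large group. Among the compounds with values here, no measured pair in this set shows such a swap, so there is no direct precedent; compounds 1 and 2 differ from each other in several places at once. A change of this kind is expected to move the number only modestly, with a slight weakening seeming somewhat more likely than a gain. The estimate for compound 3 is therefore 3 nM, with a range from 0.8 nM to 12 nM. This corresponds to an expected step of a 2.1-fold higher number from compound 2 to compound 3 (0.33 log units; beyond the scatter).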

Compound 3, half-maximal inhibitory concentration: 140 nM
The estimate for compound 3 lay 47-fold (1.67 log units) below the measured number, outside the stated range (above it).
By their numbers in this assay, from the lowest: compound 2; then compound 1; then compound 3.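

Within the data shown here, this is the first pair in the set that differs in one place only, so it gives the first clean reading of a single change in this assay. Putting sulfamoyl in place of fluoro, on an aromatic carbon meta to a large group, gives a 100-fold higher number from compound 2 to compound 3 (2.00 log units; beyond the scatter). This is a large step, and since the rest of the structure is shared, all of it belongs to this one swap, showing that this position does not accept every group equally, something the several simultaneous differences between compound 1 and compound 2 could not reveal. Nothing measured here explains why the swap has so large an effect.

As far as these compounds go, with only fluoro and sulfamoyl compared at this carbon, it remains open whether a methylsulfonyl, an amine or a carboxylic acid there would give a number closer to that of compound 2 or that of compound 3. From the compounds shown here alone, it also remains open whether the same swap at another carbon of this ring would produce a step of similar size.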